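Amine substituent trimming: cytotoxicity in the shared series

The source may hold more compounds than are shown below. What is called first, only, known or untested is meant among the compounds shown, and "the series" means these compounds.

Compound 1 `N#C/C=C/c1ccc(C(NC2CC2)c2ccnc(Nc3ccc(C#N)cc3)n2)cc1` gives 56100 nM in an ADME assay on MT4 cells (Homo sapiens) for cytotoxicity, read by MTT assay, with a stated time of 5 days; on this read-out lower numbers stand for higher toxicity in this test and higher numbers for lower toxicity in this test. Compound 3 `CCNC(c1ccc(/C=C/C#N)cc1)c1ccnc(Nc2ccc(C#N)cc2)n1` gives 37300 nM in this assay. Compound 2 `CC(O)CNC(c1ccc(C#N)cc1)c1ccnc(Nc2ccc(C#N)cc2)n1` reaches only a limit of the measurement, > 65000 nM in this assay. Compound 4 `CNC(c1ccc(C#N)cc1)c1ccnc(Nc2ccc(C#N)cc2)n1` is not yet measured.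

Within the data shown here, compound 2 therefore stands apart from compounds 1 and 3: for it no number is known, only the limit, and it is the one value of the three that sits at the limit of > 65000 nM in this assay, at which 1 of the 3 values shown sits. Compounds 1 and 3 both give numbers in this assay.

The step to compound 4 is hydrogen in place of 1-hydroxyethyl on a saturated chain carbon bound to an amine nitrogen. Among the measured compounds shown here, the one measured step touches the same region, the substituent on the amine nitrogen: a 1.5-fold lower number from compound 1 to compound 3 (0.18 log units; within the scatter). That step lies within the scatter, so a change of the amine substituent, on this evidence, moves the read-out little. For compound 4 the expectation in this assay is thus a value at or near the range where compound 2 stands, with a fair chance that only a limit is returned again.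

Compound 4 is estimated at 55000 nM, with a range from 28000 nM to 65000 nM. The expected step is an at least 1.1-fold lower number from compound 2 to compound 4 (0.07 log units; that floor lies within the scatter), not beyond the scatter.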

Compound 4, half-maximal cytotoxic concentration: 189000 nM
The estimate for compound 4 lay 3.4-fold (0.54 log units) below the measured number; measured number above the stated range.
By their numbers in this assay, from the lowest: compounds 3 and 1 (each within the scatter of the next); then compound 4.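

In this assay, among these compounds, compound 2 reaches only a limit, > 65000 nM, so the step from compound 2 to compound 4 cannot be read and these results give no new step. The compounds shown leave open the size and direction of the change from (2-hydroxypropyl)amino to methylamino in this assay.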